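A cyclopentyl group in place of a hydroxyethyl chain

The source may hold more compounds than are shown below. What is called first, only, known or untested is meant among the compounds shown, and "the series" means these compounds.

Of the compounds shown here, two sharing one core have been measured so far. Compound 1 `CC(=O)N1CCN(c2nnc3nncn3n2)CC1` carries an acetylpiperazine on the core, and in a functional assay on HL-60 cells (Homo sapiens) for inhibition, read by MTT assay, with a stated time of 72 h (on this read-out lower numbers stand for stronger inhibition and higher numbers for weaker inhibition), compound 1 gives 14700 nM. Compound 2 `OCCNc1nnc2nncn2n1` carries a 2-hydroxyethylamino group instead, and in this assay compound 2 gives 45300 nM, the highest of the two numbers, with compound 1 as its nearest neighbour at a lower value beyond the usual scatter. Compound 3 `c1nnc2nnc(NC3CCCC3)nn12` is the next member: cyclopentyl in place of 2-hydroxyethyl on a nitrogen on an aromatic ring. Within the data shown here, no measured pair shows the effect of such a change, so only the two values at hand guide the expectation. The step from the hydroxyethyl chain to the cyclopentyl ring is expected to be modest, toward a lower number and possibly inside the scatter, namely a 1.8-fold lower number from compound 2 to compound 3 (0.26 log units; within the scatter). Compound 3 is therefore estimated at 25000 nM, with a likely range from 8000 nM to 80000 nM.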

Compound 3, half-maximal inhibitory concentration: 38200 nM
Compound 3: middle estimate off by 1.5-fold (0.18 log units), on the low side, within the range that was stated.
By their numbers in this assay, from the lowest: compound 1; then compounds 3 and 2 (each within the scatter of the next).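

In this assay the exchange gives a 1.2-fold lower number from compound 2 to compound 3 (0.07 log units; within the scatter) and so lies within the scatter: on this nitrogen on an aromatic ring, the two groups cannot be told apart by their values. The cyclopentyl ring is larger than the 2-hydroxyethyl chain and has none of the hydrogen-bond donors or acceptors counted on that chain, yet this difference in structure brings no step beyond the scatter. No measurement at hand explains this result.

From the compounds shown here alone, whether any other group at this nitrogen would move the number beyond the scatter remains open, for instance a longer chain such as hexyl, a phenyl ring, or a chain ending in an amine or a carboxylic acid. Also open, going by these compounds, is whether the same exchange would give a similar step in another cell line.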